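Notes on compound 3: oxidation at the sulfur substituent

This account rests on a few compounds, and the source may have more. Where it says the series, first, only, none or still open, it means among the compounds named here.

Measured so far:
compound 1 `CCSc1nc(N)c2nc(O)n(Cc3ccccc3)c2n1`: 0.1 mg/kg
compound 2 `CCCCCSc1nc(N)c2nc(O)n(Cc3ccccc3)c2n1`: 1 mg/kg

Among the compounds with values here, in a functional assay on the whole organism for activation, with Mus musculus as the target (a lower number here means that less compound is needed, a higher number that more compound is needed for the effect), compound 2 gives 1 mg/kg, the higher of the two numbers; compound 1 gives 0.1 mg/kg, and the one measured step is a 10-fold higher number from compound 1 to compound 2 (1.00 log units; beyond the scatter). Compound 3 `CCCC[S+]([O-])c1nc(N)c2nc(O)n(Cc3ccccc3)c2n1` differs from compound 2 by a group of 6 heavy atoms (4 carbon, 1 oxygen, 1 sulfur; no ring) in place of a group of 6 heavy atoms (5 carbon, 1 sulfur; no ring), on an aromatic carbon. Within the data shown here, no measured step alters the sulfur itself; the step from compound 1 to compound 2 concerns chain length only and bears on this change only in part. The step of no change at the digits printed from compound 2 to compound 3 (within the scatter) is therefore expected to stay within the scatter. For compound 3 the estimate is 1 mg/kg, range 0.1 mg/kg to 10 mg/kg.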

Compound 3, minimum effective dose: 1 mg/kg
Compound 3: middle estimate and measured number agree at the digits printed, within the range that was stated.
By their numbers in this assay, from the lowest: compound 1; then compounds 2 and 3 (each within the scatter of the next).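

In this assay, the sulfur group carrying oxygen stands in for pentylsulfanyl on this aromatic carbon with no change at the digits printed from compound 2 to compound 3 (within the scatter), so the position accepts that exchange at this level of dose. The gap to the shorter chain remains, with a 10-fold higher number from compound 1 to compound 3 (1.00 log units; beyond the scatter), and compound 1 keeps the lowest number of the three. No available data account for this result.

The compounds shown leave open how the same oxygen on sulfur would read with the ethyl chain of compound 1. They also leave open whether an amine or a carboxylic acid at the chain end would fit this position.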